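Acylhydrazone aryl swap: a phenol replaces a fluorine

The source may hold more compounds than are shown below. What is called first, only, known or untested is meant among the compounds shown, and "the series" means these compounds.

Of the compounds shown here, two of a shared core have been tested so far. Compound 1 `CN(C)CCn1cnnc1-c1cc(Oc2ccc(NC(=O)N/N=C/c3cc(C(C)(C)C)cc(C(C)(C)C)c3O)cc2F)ccn1` and compound 2 `CN(C)CCn1cnnc1-c1cc(Oc2ccc(NC(=O)N/N=C/c3ccc(F)cc3F)cc2F)ccn1` differ only in the aryl group carried by the carbon with a double bond to nitrogen. In a functional assay on HT-29 cells (Homo sapiens) for cytotoxicity, read by MTT assay, with a stated time of 72 h (a higher number here means a weaker inhibitor, a lower number a stronger inhibitor), compound 1 gives 680 nM, and in the same measure compound 2 gives 960 nM. Compound 2 therefore holds the higher of the two numbers, but its gap to compound 1 lies within the scatter of repeated measurements, so the two cannot be ordered.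

Going by the values given here, the next compound, compound 3 `CN(C)CCn1cnnc1-c1cc(Oc2ccc(NC(=O)N/N=C/c3ccc(O)c(F)c3)cc2F)ccn1`, keeps everything else and changes only that aryl group: 3-fluoro-4-hydroxyphenyl in place of 2,4-difluorophenyl on a carbon with a double bond to nitrogen. Among the compounds with values here, no step between measured compounds that isolates this kind of change is available, so nothing measured here sets its size. Compound 1, which gives 680 nM and also carries a hydroxyl on its aryl group, stays within the scatter of compound 2.

The expectation for compound 3 is accordingly a step of a 1.2-fold lower number from compound 2 to compound 3 (0.08 log units; within the scatter) that stays within the scatter. Compound 3 is estimated at 800 nM in this assay, with a range from 350 nM to 2000 nM.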

Compound 3, half-maximal inhibitory concentration: 3310 nM
Beside the measured number, compound 3's estimate is 4.1-fold (0.62 log units) below it, outside the stated range (above it).
By their numbers in this assay, from the lowest: compounds 1 and 2 (each within the scatter of the next); then compound 3.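

In this assay this position proves able to move the number: the change from 2,4-difluorophenyl to 3-fluoro-4-hydroxyphenyl gives a 3.4-fold higher number from compound 2 to compound 3 (0.54 log units; beyond the scatter), a separation that compounds 1 and 2 had not shown, as those two lay within the scatter of each other. A hydroxyl on the aryl group does not by itself go with a higher number, since compound 1 also carries one and gives 680 nM, while compound 3 gives 3310 nM; compound 1 thus goes against any such pattern. No measurement is available that accounts for the step.

The single change brings in the hydroxyl and rearranges the fluorine at once, so the compounds shown do not tell which of the two goes with the higher number. A methoxy group in place of the hydroxyl, or an unsubstituted phenyl on the same carbon with a double bond to nitrogen, would help to separate these two parts of the change.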